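The compounds below may be only part of what the source reports. "The series", "measured", "known", "first", "only" and "open" are said of these compounds alone.

Measured compounds in a functional assay on HT-29 cells (Homo sapiens) for antiproliferative activity (on this read-out lower numbers stand for stronger inhibition and higher numbers for weaker inhibition), are as follows:
- compound 1 `COc1ccc(S(=O)(=O)N2CCc3cccc(Nc4ccc(O)cc4)c32)cc1` gives 511 nM
- compound 2 `COc1ccc(S(=O)(=O)N2CCc3cccc(Nc4ccccc4)c32)cc1` gives 343 nM
- compound 3 `COc1ccc(Nc2cccc3c2N(S(=O)(=O)c2ccc(OC)cc2)CC3)cc1` gives 803 nM

Compound 2 cannot be separated from one of its neighbours (a 1.5-fold lower number from compound 1 to compound 2 (0.17 log units; within the scatter)) but stands apart from the other (a 2.3-fold higher number from compound 2 to compound 3 (0.37 log units; beyond the scatter)) on these numbers.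

The unmeasured compound 4 `COc1ccc(S(=O)(=O)N2CCc3cccc(Nc4ccc(F)c(F)c4)c32)cc1` differs from compound 2 by one change (3,4-difluorophenyl in place of phenyl on a nitrogen on an aromatic ring), namely 3,4-difluorophenyl in place of phenyl on a nitrogen on an aromatic ring.

For the measured compounds named here, no fluorinated compound has been measured in this set. Going by the values given here, the only guides are the two steps that alter the same phenyl. One is modest (a 2.3-fold higher number from compound 2 to compound 3 (0.37 log units; beyond the scatter)) and the other stays within the scatter (a 1.5-fold lower number from compound 1 to compound 2 (0.17 log units; within the scatter)). A shift beyond the scatter is therefore not expected, though a slight drift towards a higher number would fit those two steps.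

The expected size of the change is small (a 1.3-fold higher number from compound 2 to compound 4 (0.10 log units; within the scatter)) and remains an estimate.

For compound 4 the estimated value is 430 nM with an expected range from 170 nM to 1100 nM in this read-out.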

Compound 4, half-maximal inhibitory concentration: 968 nM
The estimate for compound 4 lay 2.3-fold (0.35 log units) below the measured number; the range from low to high includes it.
By their numbers in this assay, from the lowest: compounds 2, 1, 3 and 4 (each within the scatter of the next, the first and the last beyond it).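

In this assay, the change from phenyl to 3,4-difluorophenyl on the nitrogen gives a 2.8-fold higher number from compound 2 to compound 4 (0.45 log units; beyond the scatter), a modest step and, alongside a 2.3-fold higher number from compound 2 to compound 3 (0.37 log units; beyond the scatter), a second change on this phenyl that goes beyond the scatter, though the 4-hydroxyphenyl group goes against any general pattern, with a 1.5-fold lower number from compound 1 to compound 2 (0.17 log units; within the scatter). The 3,4-difluorophenyl group cannot be separated from the other two substituted phenyl groups, with a 1.2-fold higher number from compound 3 to compound 4 (0.08 log units; within the scatter) and a 1.9-fold higher number from compound 1 to compound 4 (0.28 log units; within the scatter), so this position tolerates all three without a resolved order among them. No available data bear on the cause of the step.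

The compounds shown leave open how an amine or a carboxylic acid on this phenyl would read in this assay. Also open, from the compounds shown here alone, is whether the same step would hold with a longer chain in place of the phenyl.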